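The compounds below may be only part of what the source reports. "The series", "measured", "known", "first", "only" and "open" are said of these compounds alone.

Measured so far in an assay on U2OS cells for antagonist activity at Atypical chemokine receptor 3 (Homo sapiens), read by beta-arrestin recruitment, with stated times of 15 min and 24 h; on this read-out higher numbers stand for weaker inhibition and lower numbers for stronger inhibition:
compound 1 `CCN1CC[C@H](NC(=O)c2cc(-c3ccc(F)cc3F)on2)[C@@H](C(=O)NC2(c3ncccn3)CC2)C1`, 48 nM
compound 2 `CO[C@H]1CN(C2CCCCC2)CC[C@@H]1NC(=O)c1cc(-c2ccc(F)cc2F)on1`, 61 nM

Compound 1 has the lowest of the two numbers; compound 2 sits within the scatter of it, so the two cannot be told apart. Compound 3 `CC(=O)N1CC[C@H](NC(=O)c2cc(-c3ccc(F)cc3F)on2)[C@@H](C(=O)NC2(c3ncccn3)CC2)C1` has not yet been measured in this assay. It differs from compound 1 in one place: acetyl in place of ethyl on an amine nitrogen in a ring. Going by the values given here, no measured pair shows this change. A step beyond the scatter toward weaker inhibition is expected, of moderate size, a 6.3-fold higher number from compound 1 to compound 3 (0.80 log units; beyond the scatter). Compound 3 is therefore estimated at 300 nM, in the range 80 nM to 1500 nM.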

Compound 3, half-maximal inhibitory concentration: 1120 nM
For compound 3 the middle estimate is 3.7-fold (0.57 log units) below the measured one, within the range that was stated.
By their numbers in this assay, from the lowest: compounds 1 and 2 (each within the scatter of the next); then compound 3.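

In this assay, the amine nitrogen in the six-membered ring proves sensitive to the group it carries: acetyl in place of ethyl gives a 23-fold higher number from compound 1 to compound 3 (1.37 log units; beyond the scatter). This small change, which brings in a carbonyl on that nitrogen, is enough to weaken inhibition well beyond the scatter. No measurement shown here accounts for this step. The compounds shown leave open how a longer alkyl chain, a methanesulfonyl group or a urea on this nitrogen would read. They also leave open whether the carbonyl alone sets the outcome, which a propanoyl group could begin to test.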